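A few compounds are considered here, and "the series" means these few. Any claim that something is new, unique, unknown or untested is made for them only; others in the source may bear on it.

Two compounds share one core and were tested in a functional assay on MKN-45 cells (Homo sapiens) for inhibition, read by MTT assay, with a stated time of 72 h; a lower number here means a stronger inhibitor, a higher number a weaker inhibitor. Compound 1 `COc1cc2c(Oc3ccc(NC(=O)c4nn(-c5ccccc5C)c(=O)cc4C)cc3F)ccnc2cc1OCCCN1CCCC1` gives 760 nM in this assay. Compound 2 `COc1cc2c(Oc3ccc(NC(=O)c4nn(-c5ccccc5C)c(=O)cc4C)cc3F)ccnc2cc1OCCCN1CCCCC1` gives 1310 nM, which is the higher of the two numbers, though the gap to compound 1 is small: the step of a 1.7-fold higher number from compound 1 to compound 2 (0.24 log units; within the scatter) stays within the scatter of repeated measurements.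

Compound 3 `COc1cc2c(Oc3ccc(NC(=O)c4nn(-c5ccccc5OC(F)(F)F)c(=O)cc4C)cc3F)ccnc2cc1OCCCN1CCCCC1` has not been measured. It differs from compound 2 by trifluoromethoxy in place of methyl on an aromatic carbon. Going by the values given here, the single measured step concerns a different part of the molecule, the ring at the end of the chain, and it says nothing about swapping a methyl for a trifluoromethoxy on the aromatic ring. Among the compounds with values here, with no step bearing on this change, the expectation is that compound 3 lands near compound 2, with the estimated step of a 1.0-fold lower number from compound 2 to compound 3 (0.00 log units; within the scatter) carrying wide uncertainty. Compound 3 is therefore estimated at 1300 nM in this assay, with a range from 450 nM to 3800 nM.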

Compound 3, half-maximal inhibitory concentration: 40 nM
Estimate against measurement, compound 3: 33-fold (1.51 log units) above, and the stated range ends above it.
By their numbers in this assay, from the lowest: compound 3; then compounds 1 and 2 (each within the scatter of the next).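

Changing the group on this aromatic carbon matters far more in this assay than changing the ring at the end of the chain: going from 2-methylphenyl to 2-(trifluoromethoxy)phenyl gives a 33-fold lower number from compound 2 to compound 3 (1.52 log units; beyond the scatter), a step beyond the scatter, whereas the ring change gives a 1.7-fold higher number from compound 1 to compound 2 (0.24 log units; within the scatter). So this position, ortho to a large group, responds strongly to the group it carries, at least in this one pair. Nothing measured here on the properties of these two groups accounts for the result.

The compounds shown leave open whether the oxygen, the fluorines or both are needed, a question that methoxy or trifluoromethyl on the same carbon would address. Going by these compounds, it also remains open whether the same swap would give a similar step with the pyrrolidin-1-yl chain end of compound 1.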